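This account rests on a few compounds, and the source may have more. Where it says the series, first, only, none or still open, it means among the compounds named here.

Compound 1 `COc1ccc(C2SCC(=O)N2CCN2CCCCC2)cc1`: 33%. Compound 2 `O=C1CSC(c2cccc(Cl)c2)N1CCN1CCCCC1`: 31%. Compound 3 `COc1ccccc1C1SCC(=O)N1CCN1CCCCC1`: 30%.

In an ADME assay on Vero cells (Chlorocebus sabaeus) for cytotoxicity, read by neutral red uptake, tested at 787 ug/mL (on this read-out lower numbers stand for a stronger effect and higher numbers for a weaker effect at the one concentration tested), compound 1 gives 33%, the highest of the three numbers. Compound 2 gives 31% and compound 3 gives 30%, both within the scatter of compound 1, so no order among the three can be claimed. Compound 4 `Cc1ccc(C2SCC(=O)N2CCN2CCCCC2)cc1` has not yet been measured. It differs from compound 1 by methyl in place of methoxy on an aromatic carbon. Within the data shown here, no step between two measured compounds covers a change of this kind, and the three measured numbers cluster closely, so in this assay no step beyond the scatter is expected in either direction. The step of a number 1 percentage points lower from compound 1 to compound 4 (within the scatter) is expected to stay within the scatter. Compound 4 is estimated at 32%, with a range from 20% to 45%.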

Compound 4, a percentage reported as activity, at one concentration (the size of the read-out at that concentration, not a potency): 17%
Compound 4: middle estimate off by 15 percentage points, on the high side; the whole stated range lies above it.
By their numbers in this assay, from the lowest: compound 4; then compounds 3, 2 and 1 (each within the scatter of the next).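

Among these compounds, at the place para to a large group, this assay does respond to a change: methyl in place of methoxy gives a number 16 percentage points lower from compound 1 to compound 4 (beyond the scatter) and is the first difference beyond the scatter in this set. Compound 4 also separates from compound 2, with 4-methylphenyl in place of 3-chlorophenyl giving a number 14 percentage points lower from compound 2 to compound 4 (beyond the scatter) as a second step beyond the scatter. Nothing shown here explains why the number moves. As far as these compounds go, whether ethyl or chlorine at that same place would give a similar number stays open. So does whether methyl would have the same effect on the other ring positions held by compounds 2 and 3.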